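The source may hold more compounds than are shown below. What is called first, only, known or untested is meant among the compounds shown, and "the series" means these compounds.

In a functional assay on Col1 cells (Homo sapiens) for cytotoxicity, read by sulforhodamine B assay, with a stated time of 72 h (on this read-out lower numbers stand for an effect already at smaller amounts and higher numbers for an effect only at larger amounts of compound), compound 3 `CCCC[C@H](OC(C)=O)[C@@H](OC(C)=O)[C@H](OC(C)=O)[C@H]1CC=CC(=O)O1` gives 4 ug/mL. Compound 1 `CCCC[C@H](OC(C)=O)[C@@H](O)[C@H](O)[C@@H]1OC(=O)C=C[C@@H]1OC(C)=O` gives 5.1 ug/mL, so the two numbers lie within the scatter of each other. Compound 2 `CCCC[C@@H](/C=C\[C@@H]1OC(=O)C[C@@H](OC)[C@@H]1O)OC(C)=O` is reported only as a limit, > 20 ug/mL. Compound 3 therefore shares its place on these numbers with compound 1, and neither can be ranked ahead of the other.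

Compound 4 `CCCC[C@H](OC(C)=O)[C@@H](OC(C)=O)[C@H](OC(C)=O)[C@@H]1OC(=O)C=C[C@@H]1OC(C)=O` is reached from compound 3 by one change, acetoxy in place of hydrogen on a saturated ring carbon, next to the ring atom that bears a large group. Among the compounds with values here, no measured pair isolates this change. The nearest guide is compound 1, which also carries acetoxy on a saturated ring carbon and gives 5.1 ug/mL, a number within the scatter of the value of compound 3. No change beyond the scatter is therefore expected in this assay. The estimated size of the step is a 1.1-fold lower number from compound 3 to compound 4 (0.06 log units; within the scatter). For compound 4 the expected value is 3.5 ug/mL, with an estimated range from 1.2 ug/mL to 10 ug/mL.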

Compound 4, concentration for half-maximal effect: 4.9 ug/mL
The estimate for compound 4 lay 1.4-fold (0.15 log units) below the measured number, within the range that was stated.
By their numbers in this assay, from the lowest: compounds 3, 4 and 1 (each within the scatter of the next). At a limit, above all of these: compound 2.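

Within the data shown here, compound 3 and compound 4 form the first measured pair that isolates this change, and in this assay the step is a 1.2-fold higher number from compound 3 to compound 4 (0.09 log units; within the scatter) for acetoxy in place of hydrogen on a saturated ring carbon. This position, next to the ring atom that bears a large group and two ring bonds from the ring oxygen, therefore takes acetoxy without a change beyond the scatter on this read-out. Nothing shown gives a cause for this step.

The compounds shown leave open whether a different group at this position, such as an amine, a carboxylic acid or a longer chain, would move the number beyond the scatter. They also leave open whether a free hydroxy group here would read like acetoxy or differently.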